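The source may hold more compounds than are shown below. What is called first, only, known or untested is meant among the compounds shown, and "the series" means these compounds.

In a functional assay on T98G cells (Homo sapiens) for inhibition, read by colorimetric assay and MTT assay, with a stated time of 72 h (a higher number here means a weaker inhibitor, a lower number a stronger inhibitor), three compounds have been measured so far. Compound 1 `COc1ccc2c(c1)-c1cnc(n1C)OCCCCCCCCO2` gives 68000 nM and compound 2 `Cn1c2cnc1OCCCCCCCCCOc1ccccc1-2` gives 74000 nM as its value, and these two numbers lie within the usual scatter of each other. Compound 3 `C=CCCCCOc1ncc(-c2cc(C(C)C)ccc2OC)n1C` gives 6000 nM as the lowest of the three numbers, and its gaps to the other two lie beyond the scatter.

Compound 4 `C=CCCCCOc1ncc(-c2cc(C(F)(F)F)ccc2OC)n1C` has not been measured yet. It differs from compound 3 in one place, with trifluoromethyl in place of isopropyl on an aromatic carbon para to a methoxy group. Among the compounds with values here, no measured pair of compounds shows this change, so the data give no direct guide to its size. In this assay the expectation is therefore a small rise in the number, meaning a somewhat weaker inhibitor, by an amount close to the scatter. Compound 3 at 6000 nM already holds the lowest number of the measured set, so a rise is judged likelier than a further fall. The estimated change is a 1.5-fold higher number from compound 3 to compound 4 (0.18 log units; within the scatter) and it remains uncertain. For compound 4 the estimated value is 9000 nM with an expected range from 3000 nM to 30000 nM once it is tested.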

Compound 4, half-maximal inhibitory concentration: 88000 nM
Estimate against measurement, compound 4: 9.8-fold (0.99 log units) below; the whole stated range lies below it.
By their numbers in this assay, from the lowest: compound 3; then compounds 1, 2 and 4 (each within the scatter of the next).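

In this assay, putting trifluoromethyl in place of isopropyl on the aromatic carbon para to a methoxy group gives a 15-fold higher number from compound 3 to compound 4 (1.17 log units; beyond the scatter). Within the data shown here, this is the first comparison in the set in which only one place changes, and it shows that this position is not indifferent: exchanging one small group for another, with no hydrogen-bond donors or acceptors and no net charge on either, is enough to produce a large step. No supporting measurement accompanies this result, so the data offer no explanation for the size of the step.

From the compounds shown here alone, a single step between two groups cannot show how the number responds across a wider range of groups at this position, so it remains open where a methyl group, a chlorine atom, an amine or a carboxylic acid would fall relative to compound 3 and compound 4. Among these compounds, it also remains open whether the same exchange would give a step of similar size if a longer chain replaced the one that compound 3 and compound 4 share.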